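Mirror-image pair in a kinetic solubility assay

The compounds below may be only part of what the source reports. "The series", "measured", "known", "first", "only" and "open" are said of these compounds alone.

Compound 1 `Cc1cc(C)c(CN2CCc3c(Cl)cc([C@@H](CO)[C@@H]4CCCO4)c(Cl)c3C2=O)c(=O)[nH]1`: 550000 nM
Compound 2 `COc1cc(C)[nH]c(=O)c1CN1CCc2c(Cl)cc(C(OC)C3(C)COC3)c(Cl)c2C1=O`: 486000 nM; 512000 nM (2 entries)

In a physicochemical assay for solubility, measured as kinetic solubility (on this read-out lower numbers stand for lower solubility and higher numbers for higher solubility), compound 1 gives 550000 nM, the only number shown for it, and compound 2 sits close by, its repeated entries the several entries of compound 2 in this assay, 486000 nM; 512000 nM (2 entries) falling close together. Compound 3 `Cc1cc(C)c(CN2CCc3c(Cl)cc([C@H](CO)[C@H]4CCCO4)c(Cl)c3C2=O)c(=O)[nH]1` differs from compound 1 only in configuration: the two compounds have the same atoms and bonds and differ only in configuration as drawn: 2 of 2 stereo elements differ (all stereocentres are inverted: mirror images); a stereocentre at a saturated chain carbon is drawn S in compound 1 and R in compound 3; a stereocentre at a saturated ring carbon is drawn S in compound 1 and R in compound 3. The same atoms and bonds in mirror image give no reason to expect a step beyond the usual scatter in this assay, in either direction. Compound 3 is therefore expected to give 550000 nM, between 300000 nM and 950000 nM, an estimated step of no change at the digits printed from compound 1 to compound 3 (within the scatter).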

Compound 3, solubility: 430000 nM
Estimate against measurement, compound 3: 1.3-fold (0.11 log units) above; low and high end bracket the measured number.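

In this assay, the full inversion of both stereocentres gives a 1.3-fold lower number from compound 1 to compound 3 (0.11 log units; within the scatter), so this mirror-image pair is not separated at this position. The earlier compounds offered no such reading of configuration alone, and here nothing else changes: the fact that compounds 1 and 3 differ only in the configuration as drawn

Going by these compounds, whether inverting a single stereocentre would read the same stays open. So does the reading of a compound with an amine or a carboxylic acid in place of the hydroxyl group, since configuration here was tested with that one set of atoms only.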